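The source may hold more compounds than are shown below. What is called first, only, known or untested is meant among the compounds shown, and "the series" means these compounds.

In an assay on isolated protein for inhibition of Dihydrofolate reductase (Mus musculus) (a lower number here means a less potent compound, a higher number a more potent compound, by a factor of ten per unit of this negative logarithm), compound 2 `CC1(C)N=C(N)N=C(N)N1c1cccc(CNC(=O)Nc2cccc(C#N)c2)c1` gives 8.19, the higher of the two values available, while compound 1 `CC1(C)N=C(N)N=C(N)N1c1ccc(OCCCC(=O)Nc2cccc(S(=O)(=O)F)c2)c(Cl)c1` gives 7.17 in this assay, a lower value whose gap to compound 2 is beyond the usual scatter. Compound 3 `CCN(CC)C(=O)NCc1cccc(N2C(N)=NC(N)=NC2(C)C)c1` differs from compound 2 in a single place: diethylamino in place of (3-cyanophenyl)amino on a carbonyl carbon. For the measured compounds named here, with no measured pair showing this change, the loss of the aromatic ring and of its hydrogen-bond donor is expected to cost potency. For compound 3 the expected step of a number 0.79 log units lower from compound 2 to compound 3 (beyond the scatter) is a drop, and the estimated value in this assay is 7.4, between 6.6 and 8.2.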

Compound 3, logarithm of the reciprocal of the active concentration, log(1/C): 6.11
Compound 3: middle estimate off by 1.29 log units, on the high side; measured number outside the range, below it.
By their numbers in this assay, from the lowest: compound 3; then compound 1; then compound 2.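

With the shared core unchanged, putting diethylamino in place of (3-cyanophenyl)amino on a carbonyl carbon gives, in this assay and as a large change, a number 2.08 log units lower from compound 2 to compound 3 (beyond the scatter), so what sits at this position matters greatly. The swap removes the aromatic ring, the nitrile and a hydrogen-bond donor together, so this one step cannot single out any of them. Nothing at hand explains the drop. The compounds shown leave open which of these parts counts. Plain phenylamino, without the nitrile, or ethylamino, which keeps the amine hydrogen but has no ring, would be the groups to separate them.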